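This account rests on a few compounds, and the source may have more. Where it says the series, first, only, none or still open, it means among the compounds named here.

Working notes on the series. Compound 1 `Cc1cc(C)c(NC(=O)N(Cc2ccc(-c3ccsc3)cc2)C2CCCCCC2)c(C)c1` carries a thiophen-3-yl group on the six-membered carbon ring; in a functional assay on a cell-free system (plasma) with sterol O-acyltransferase, Soat (Rattus norvegicus) as the target (a higher number here means that more compound is needed for the effect, a lower number that less compound is needed), compound 1 gives 0.51 mg/kg. Compound 2 `Cc1cc(C)c(NC(=O)N(Cc2ccc(-c3ccn(C)n3)cc2)C2CCCCCC2)c(C)c1` carries a 1-methyl-1H-pyrazol-3-yl group in the same place. In this assay compound 2 gives only a limit, < 1 mg/kg, so no number is known for it. The step that the limit leaves unreadable from compound 1 to compound 2 therefore cannot be sized, because of the limit of < 1 mg/kg in this assay, at which 1 of the 2 values shown sits, only a limit is available for compound 2. Compound 3 `Cc1cc(C)c(NC(=O)N(Cc2ccc(-n3ccnn3)cc2)C2CCCCCC2)c(C)c1` is the next member, differing from compound 2 by 1H-1,2,3-triazol-1-yl in place of 1-methyl-1H-pyrazol-3-yl on an aromatic carbon. Among the measured compounds shown here, no measured step in this set bears on this change; the sole sized value, that of compound 1, sits close to the limit of compound 2, and both point to the same general region. For compound 3 no step beyond the scatter is expected, a step that the limit leaves unreadable from compound 2 to compound 3. The estimate for compound 3 in this assay is 0.7 mg/kg, expected to fall between 0.2 mg/kg and 2.5 mg/kg.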

Compound 3, dose for half-maximal effect: > 1 mg/kg
Compound 3: no number, only a limit; the forecaster's own chance of this, stated with the estimate: 40%; middle value at least 1.4-fold (0.15 log units) away from the limit.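

In this assay compound 3 gives only a limit, > 1 mg/kg. Putting 1H-1,2,3-triazol-1-yl in place of thiophen-3-yl on this aromatic carbon, para to a large group, gives an at least 1.9-fold higher number from compound 1 to compound 3 (0.29 log units; that floor lies within the scatter), so the position now has its first readable floor on a step, though that floor stays within the scatter. Putting 1H-1,2,3-triazol-1-yl in place of 1-methyl-1H-pyrazol-3-yl on this aromatic carbon gives a number no lower from compound 2 to compound 3 (the limit leaves the size open). The size of the steps that involve compound 2 cannot be read, as its result is also only a limit.

Going by these compounds, how far the true value of compound 3 lies beyond that floor remains open, as does the place of compound 2 relative to the other two compounds. Also open, on these data alone, is how an amine or a carboxylic acid on this aromatic carbon would read in this assay.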